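The source may report more compounds than this note shows. Statements on the series, on what has been measured and on what is new or still open speak of the compounds shown alone.

Three compounds have been measured in a functional assay on the whole organism (strain Swiss albino) for inhibition, with Mus musculus as the target, in the writhing test, with stated times of 60 min and 15 min, at a dose of 100 mg/kg by the oral route; a higher number here means more inhibition at the dose given (going by the name of the read-out), a lower number less inhibition:

Compound 1, `COc1cc2c(cc1OC)C(CC(=O)O)CC2`, gives 44%.
Compound 2, `COc1cc2c(cc1OC)C(CC(N)=O)CC2`, gives 24.6%.
Compound 3, `CCN(CC)C(=O)CC1CCc2cc(OC)c(OC)cc21`, gives 27.4%.

Compound 3 does not stand out from these numbers. The step of a number 2.8 percentage points higher from compound 2 to compound 3 (within the scatter) is within the scatter, so the two amide-bearing compounds cannot be told apart here, while the step of a number 16.6 percentage points lower from compound 1 to compound 3 (beyond the scatter) is beyond the scatter, as is the step of a number 19.4 percentage points lower from compound 1 to compound 2 (beyond the scatter). Both steps away from the acid of compound 1 therefore point the same way and are of modest size.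

Compound 4, `COc1cc2c(cc1OC)C(CC(=O)NC1CCCC1)CC2`, carries the change (cyclopentylamino in place of diethylamino on a carbonyl carbon). Going by the values given here, the only measured step that bears on swapping one amine for another at this carbonyl carbon is a number 2.8 percentage points higher from compound 2 to compound 3 (within the scatter), and it lies within the scatter. In this assay the step of a number 0.6 percentage points higher from compound 3 to compound 4 (within the scatter) is therefore expected to stay within the scatter, with no clear direction. Compound 4 is estimated at 28%, within the range 15% to 42%.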

Compound 4, a percentage reported as inhibition, in the whole organism at one dose (the size of the read-out at that dose, not a potency): 37%
Estimate against measurement, compound 4: 9 percentage points below; the measured number falls inside the stated range.
By their numbers in this assay, from the lowest: compounds 2, 3, 4 and 1 (each within the scatter of the next, the first and the last beyond it).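

In this assay, going by these compounds alone, the group on the amide nitrogen now makes a readable difference: cyclopentyl in place of hydrogen gives a number 12.4 percentage points higher from compound 2 to compound 4 (beyond the scatter), the only step among the amides that clears the scatter. Cyclopentylamino and diethylamino cannot be separated, since the exchange gives a number 9.6 percentage points higher from compound 3 to compound 4 (within the scatter), so the data do not rank these two amides. Compound 4 is also the only amide that cannot be separated from the acid, with a number 7 percentage points lower from compound 1 to compound 4 (within the scatter), which shows that replacing hydroxy on the carbonyl carbon need not bring a clear loss in this test.

Nothing available explains these differences. Going by these compounds, whether cyclohexyl or isopropyl on the amide nitrogen would also stay close to compound 1 remains open, and a reading at one dose says nothing about potency.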